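Swapping a dimethoxyphenyl for fluorophenyl on a hydrazone-derived core

A few compounds are considered here, and "the series" means these few. Any claim that something is new, unique, unknown or untested is made for them only; others in the source may bear on it.

Measured so far:
- compound 1, `COc1cc(C2=NN(C(C)=O)C(c3cccc(OC)c3OC)O2)cc(OC)c1OC`: 3.8%
- compound 2, `COc1cc(/C=N/NC(=O)c2cc(OC)c(OC)c(OC)c2)cc(OC)c1OC`: -5%

Both numbers come from a functional assay on BGC-823 cells (Homo sapiens) for antiproliferative activity, read by MTT assay, tested at 1 uM; a higher number here means a stronger effect of the compound at the concentration tested, a lower number a weaker effect. In this assay compound 1 gives 3.8%, the highest of the two numbers shown. Compound 2, an open-chain relative of the same trimethoxyphenyl-bearing core, gives -5%; the gap between the two compounds lies within the scatter, so neither can be called stronger than the other. At this concentration, both compounds sit close to no effect.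

Compound 3, `COc1cc(C2=NN(C(C)=O)C(c3cccc(F)c3)O2)cc(OC)c1OC`, has not yet been measured. It differs from compound 1 in one place: 3-fluorophenyl in place of 2,3-dimethoxyphenyl on a saturated ring carbon

Among the measured compounds shown here, no step between measured compounds is available to guide this change. With both known values near zero, no step beyond the scatter is expected in this assay, in either direction. Compound 3 is therefore estimated at 5%, with a range from -10% to 20%, which means an expected step of a number 1.2 percentage points higher from compound 1 to compound 3 (within the scatter).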

Compound 3, a percentage reported as inhibition, at one concentration (the size of the read-out at that concentration, not a potency): 14.7%
For compound 3 the middle estimate is 9.7 percentage points below the measured one; low and high end bracket the measured number.
By their numbers in this assay, from the lowest: compounds 2 and 1 (each within the scatter of the next); then compound 3.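

In this assay, the aryl group on this saturated ring carbon turns out to matter: 3-fluorophenyl in place of 2,3-dimethoxyphenyl gives a step of a number 10.9 percentage points higher from compound 1 to compound 3 (beyond the scatter). The earlier compounds could not show this, as they offered no one-place change, and this is the only step shown so far, resting on a single concentration. No measurement shown accounts for the step.

The swap removes two methoxy groups and adds a fluorine at once, so the compounds shown leave open which of these changes carries the step. A plain phenyl on this ring carbon would help separate the two, and a phenyl bearing an amine or a carboxylic acid would test how far this position tolerates quite different groups.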